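The source may report more compounds than this note shows. Statements on the series, on what has been measured and on what is new or still open speak of the compounds shown alone.

Measured compounds:
compound 1 `CCCCc1ccc2ncc(-c3nn[nH]n3)cc2c1` – 5 mg/kg
compound 2 `COc1ccc(OC)c2ncc(C(=O)O)cc12` – > 25 mg/kg

Of the compounds shown here, two have been tested in a functional assay on the whole organism (strain Sprague-Dawley) for inhibition, with Rattus norvegicus as the target; on this read-out lower numbers stand for an effect already at smaller amounts and higher numbers for an effect only at larger amounts of compound. Among the compounds with values here, compound 1 is the only one that yields a number; in this assay compound 1 gives 5 mg/kg. Compound 2 gives no number, only a limit of the assay: in this assay compound 2 reaches > 25 mg/kg. Within the data shown here, that result is the limit of > 25 mg/kg in this assay, at which 1 of the 2 values shown sits, and it sets no step against compound 1.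

Compound 3 `Fc1ccc2ncc(-c3nn[nH]n3)cc2c1` has not yet been measured. It departs from compound 1 at one point: fluoro in place of butyl on an aromatic carbon. Among the measured compounds shown here, no pair of measured compounds that differ in a single place exists here, so the size of this step can only be expected, not read off. Compound 3 is expected to need a somewhat larger amount than compound 1, a step of a 3.0-fold higher number from compound 1 to compound 3 (0.48 log units; beyond the scatter) in this assay. Compound 3 is estimated at 15 mg/kg, within a range from 5 mg/kg to 50 mg/kg.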

Compound 3, minimum effective dose: < 25 mg/kg
Compound 3: no number, only a limit; the forecaster's own chance of this, stated with the estimate: 35%; the middle value is on the limit's open side.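

No step can be read between compound 1 and compound 3, because compound 3 gives only a limit of the assay and no number: the limit of < 25 mg/kg in this assay, at which 1 of the 3 values shown sits.

The compounds shown leave open how much fluoro in place of butyl on an aromatic carbon changes the result in this assay.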